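Shared-core series: replacing the aromatic amino group

The compounds below may be only part of what the source reports. "The series", "measured", "known", "first", "only" and "open" are said of these compounds alone.

compound 1 `Nc1cc2c(-n3nc(-c4ccccn4)nc3N)ncnc2cc1Cl`: > 40000 nM
compound 2 `COc1cc2ncnc(-n3nc(-c4ccccn4)nc3N)c2cc1N`: > 40000 nM
compound 3 `COc1cc2ncnc(-n3nc(C4CCCCC4)nc3N)c2cc1OC`: > 40000 nM

In an assay on MCF7 cells for inhibition of Serine-protein kinase ATM (Homo sapiens), read by immunofluorescence, with a stated time of 1 h (on this read-out higher numbers stand for weaker inhibition and lower numbers for stronger inhibition), compound 1 gives > 40000 nM, which is a limit of the assay and not a number. In this assay compound 2 gives > 40000 nM, again only a limit. Compound 3 gives > 40000 nM in this assay, also a limit. the limit of > 40000 nM in this assay, at which 3 of the 3 values shown sit, covers every value shown, so compound 2 stands at the limit together with the other two, and no order among the three can be read. Within the data shown here, the single step between measured compounds, a step that the two limits leave unreadable from compound 1 to compound 2, cannot be sized, both of its ends being limits.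

Compound 4 `COc1cc2ncnc(-n3nc(-c4ccccn4)nc3N)c2cc1OCCCN1CC(C)OC(C)C1` differs from compound 2 by 3-(2,6-dimethylmorpholin-4-yl)propoxy in place of amino on an aromatic carbon. No measured step bears on this change: the one step shown touches a different group, and every value sits at the limit. Among the measured compounds shown here, the expectation for compound 4 in this assay therefore rests on no measured step and must be wide. The step from compound 2 to compound 4 is expected to be an at least 8.0-fold lower number from compound 2 to compound 4 (0.90 log units; beyond the scatter), with its direction not readable from the data. Compound 4 is expected at 5000 nM, in a range from 200 nM to 40000 nM.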

Compound 4, half-maximal inhibitory concentration: 1600 nM
Beside the measured number, compound 4's estimate is 3.1-fold (0.49 log units) above it; the measured number falls inside the stated range.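

Of the compounds shown, only compound 4 gives a value off the limit in this assay, which shows that the aromatic carbon ortho to a methoxy group can carry a change that moves this read-out. With 3-(2,6-dimethylmorpholin-4-yl)propoxy in place of amino, the result is an at least 25-fold lower number from compound 2 to compound 4 (1.39 log units; beyond the scatter). Compound 2 gives only a limit, so this step has a bound and not an exact size: the limit of > 40000 nM in this assay, at which 3 of the 4 values shown sit.

The compounds shown do not separate the contributions of the propoxy chain and the 2,6-dimethylmorpholine ring, a question that a plain morpholine, a piperidine or a shorter ethoxy chain on the same carbon would address. Going by these compounds, it also remains open whether the same chain would give a similar step with the cyclohexyl group of compound 3 in place of the pyridine ring.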